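Swapping 1-Hydroxyethyl for 4-Aminobutyl in Compound 4

This account rests on a few compounds, and the source may have more. Where it says the series, first, only, none or still open, it means among the compounds named here.

Three compounds share one core and differ only in the side chain on the saturated chain carbon bound to an amide-type nitrogen and a carbonyl carbon. In a functional assay on the whole organism (Tail, strain ICR) with Mus musculus as the target, in the tail flick test, with a stated time of 120 min, at a dose of 25 umol/kg by the oral route (a higher number here means a stronger effect of the compound at the dose given, a lower number a weaker effect), compound 1 `O=C(CN(c1nc(Cl)nc2[nH]cnc12)C1CC1)N[C@@H](CO)C(=O)O` gives 39%, compound 2 `NC(=O)C[C@H](NC(=O)CN(c1nc(Cl)nc2[nH]cnc12)C1CC1)C(=O)O` gives 17%, and compound 3 `C[C@@H](O)[C@H](NC(=O)CN(c1nc(Cl)nc2[nH]cnc12)C1CC1)C(=O)O` gives 37.6%. Compound 3 thus stands second highest of the three, with compound 1 within the scatter of it and compound 2 well below it, as the step of a number 20.6 percentage points higher from compound 2 to compound 3 (beyond the scatter) shows. The other step, a number 22 percentage points lower from compound 1 to compound 2 (beyond the scatter), points the same way: the carbamoyl-bearing chain sits lowest.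

Compound 4 `NCCCC[C@H](NC(=O)CN(c1nc(Cl)nc2[nH]cnc12)C1CC1)C(=O)O` carries 4-aminobutyl in place of 1-hydroxyethyl on a saturated chain carbon bound to an amide-type nitrogen and a carbonyl carbon. Among the measured compounds shown here, no measured step matches this change closely; the two steps above concern hydroxy against carbamoyl and were modest in size. A chain with a different donor and acceptor is therefore expected to move this assay by a modest amount, most likely downward. Compound 4 is estimated at 28%, between 8% and 50%, an expected step of a number 9.6 percentage points lower from compound 3 to compound 4 (within the scatter).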

Compound 4, a percentage reported as activity, at one dose (the size of the read-out at that dose, not a potency): 16.4%
Compound 4: the middle estimate sits 11.6 percentage points above what was measured; low and high end bracket the measured number.
By their numbers in this assay, from the lowest: compounds 4 and 2 (each within the scatter of the next); then compounds 3 and 1 (each within the scatter of the next).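

In this assay, the change from 1-hydroxyethyl to 4-aminobutyl gives a number 21.2 percentage points lower from compound 3 to compound 4 (beyond the scatter) and, measured against the other hydroxy-bearing chain, a number 22.6 percentage points lower from compound 1 to compound 4 (beyond the scatter) at this position, so a second chain without a hydroxy group now sits low. Set against the carbamoyl-bearing chain, the same chain gives a number 0.6 percentage points lower from compound 2 to compound 4 (within the scatter) and thus no separation, which leaves the four compounds in two groups: compound 1 with compound 3, carrying a hydroxy group, and compound 2 with compound 4, lacking one. No supporting measurement accounts for this split.

From the compounds shown here alone, whether the terminal amine or the longer chain matters here stays open, since a plain butyl chain or a 4-hydroxybutyl chain would separate the two. A carboxylic acid at the end of the chain would also show whether other end groups share this low level.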